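The source may report more compounds than this note shows. Statements on the series, on what has been measured and on what is new or still open speak of the compounds shown alone.

Compounds measured:
compound 1 `N#CC1=C(N)Oc2c(c3nc4ccccc4nc3c3ccccc23)C12C(=O)N(Cc1cnnn1-c1ccccc1Br)c1ccccc12` — in an ADME assay on L02 cells (Homo sapiens) for antiproliferative activity, read by MTT assay, with a stated time of 48 h (on this read-out higher numbers stand for weaker inhibition and lower numbers for stronger inhibition), compound 1 gives > 50000 nM, a limit of the assay.
compound 2 `COc1ccc(-n2nncc2CN2C(=O)C3(C(C#N)=C(N)Oc4c3c3nc5ccccc5nc3c3ccccc43)c3ccccc32)cc1` — compound 2 gives > 50000 nM, a limit of the assay.
compound 3 `N#CC1=C(N)Oc2c(N)cc3nc4ccccc4nc3c2C12C(=O)N(Cc1cnnn1-c1ccc(Cl)cc1)c1ccccc12` — compound 3 gives > 50000 nM, a limit of the assay.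

Compound 3 thus stands at the same limit as the other two, with no number of its own. Going by the values given here, the one counted step, a step that the two limits leave unreadable from compound 1 to compound 2, joins two limits and shows nothing readable. Compound 4 `CCOc1ccc(-n2nncc2CN2C(=O)C3(C(C#N)=C(N)Oc4c(N)cc5nc6ccccc6nc5c43)c3ccccc32)cc1` differs from compound 3 by ethoxy in place of chloro on an aromatic carbon. Among the compounds with values here, no measured step bears on this change; the only evidence is the limit of > 50000 nM in this assay, at which 3 of the 3 values shown sit, so no step beyond the scatter is expected in either direction. Compound 4 is therefore expected to stay at the limit, an estimated 70000 nM within 30000 nM to 200000 nM, an expected step that the limit leaves unreadable from compound 3 to compound 4.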

Compound 4, half-maximal inhibitory concentration: > 50000 nM
Compound 4 was reported as a limit; the forecaster's own chance of this, stated with the estimate: 85%; the middle value does not contradict the limit.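

Compound 3 and compound 4 both stand at a limit of this assay, so no new step can be read between them. The compounds shown leave open whether ethoxy in place of chloro changes this read-out at all.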